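Swapping fluoro for trifluoromethyl on the aryl ring

The source may report more compounds than this note shows. Statements on the series, on what has been measured and on what is new or still open speak of the compounds shown alone.

Compound 2 has the structure `CC(C(=O)N1CCN(c2ccccc2F)CC1)N1C(=O)CCC1=O`. In a functional assay on the whole organism (strain Swiss) with Mus musculus as the target, in the maximal electroshock model, with a stated time of 0.5 h, at a dose of 300 mg/kg by the intraperitoneal route (on this read-out lower numbers stand for a weaker effect and higher numbers for a stronger effect at the one dose given), compound 2 gives 50%. Among the compounds with values here, compound 1, with structure `CC(C(=O)N1CCN(c2ccccc2)CC1)N1C(=O)CCC1=O`, gives 50% in this assay, so compound 2 stands level with it; the only step measured so far, no change at the digits printed from compound 1 to compound 2 (within the scatter), stayed within the scatter. Compound 3, with structure `CC(C(=O)N1CCN(c2ccccc2C(F)(F)F)CC1)N1C(=O)CCC1=O`, has not yet been measured. It differs from compound 2 by trifluoromethyl in place of fluoro on an aromatic carbon. Within the data shown here, the one step that bears on this change is the earlier exchange on the same aromatic carbon, and it produced no movement in this assay. Among the measured compounds shown here, with only that step as a guide, the expectation for the exchange to trifluoromethyl is likewise a step of no size beyond the scatter, namely no change at the digits printed from compound 2 to compound 3 (within the scatter). Compound 3 is therefore estimated to give 50% in this assay, with an expected range from 25% to 75%.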

Compound 3, a percentage reported as activity, at one dose (the size of the read-out at that dose, not a potency): 100%
Estimate against measurement, compound 3: 50 percentage points below; measured number outside the range, above it.
By their numbers in this assay, from the lowest: compounds 1 and 2 (each within the scatter of the next); then compound 3.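

In this assay, the aromatic carbon ortho to a large group proves sensitive to what it carries: trifluoromethyl in place of fluoro gives a number 50 percentage points higher from compound 2 to compound 3 (beyond the scatter) and, set against hydrogen, it gives a number 50 percentage points higher from compound 1 to compound 3 (beyond the scatter) in the same read-out. Within the data shown here, the earlier exchange of hydrogen for fluoro, with no change at the digits printed from compound 1 to compound 2 (within the scatter) as its result, therefore showed only that this one small swap changed nothing, not that the position is indifferent to substitution. No measurement at hand offers an explanation for the difference between fluoro and trifluoromethyl here.

The compounds shown leave open whether a methyl, a methoxy group or a chlorine on this carbon would match trifluoromethyl, and whether trifluoromethyl elsewhere on the ring would act the same way. Results at a single dose also tell only of a stronger or weaker effect at that dose.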